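Amide substituent change on the shared core

The compounds below may be only part of what the source reports. "The series", "measured", "known", "first", "only" and "open" are said of these compounds alone.

Three compounds share a core bearing a diethylsulfamoyl-substituted benzenesulfonyl group on a saturated nitrogen ring and have been measured in a functional assay on BXPC-3 cells (Homo sapiens) for inhibition, read by MTT assay, with a stated time of 7 days; a lower number here means a stronger inhibitor, a higher number a weaker inhibitor. Compound 1 `CCN(CC)S(=O)(=O)c1ccc(S(=O)(=O)N2CCC[C@@H](C(=O)N[C@@H]3CCN(C(=O)OC(C)(C)C)C3)C2)cc1` carries an amide whose nitrogen bears a 1-(tert-butoxycarbonyl)pyrrolidin-3-yl group; in this assay compound 1 gives 400 nM. Compound 2 `CCOC(=O)[C@@H]1C[C@H](O)CN(S(=O)(=O)c2ccc(S(=O)(=O)N(CC)CC)cc2)C1` replaces the amide with an ethyl ester and carries a hydroxyl on the ring; in this assay compound 2 gives 3300 nM. Compound 3 `CCOC(=O)[C@H]1CCN(S(=O)(=O)c2ccc(S(=O)(=O)N(CC)CC)cc2)C1`, the plain ethyl ester, gives 29300 nM in this assay. Compound 1 stands lowest of the three, and both gaps, to compound 2 and to compound 3, lie beyond the scatter, so compound 1 is the strongest inhibitor of those measured.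

Compound 4 `CCN(CC)S(=O)(=O)c1ccc(S(=O)(=O)N2CCC[C@@H](C(=O)NC3COC3)C2)cc1` differs from compound 1 in one place: oxetan-3-yl in place of 1-(tert-butoxycarbonyl)pyrrolidin-3-yl on an amide-type nitrogen. Within the data shown here, no measured pair shows this change, so its size is a matter of expectation. The two smaller-substituent compounds 2 and 3 give much higher numbers than compound 1, and an upward step beyond the scatter is expected here as well, a 7.5-fold higher number from compound 1 to compound 4 (0.88 log units; beyond the scatter). Compound 4 is thus estimated at 3000 nM in this assay, within a range of 600 nM to 15000 nM.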

Compound 4, half-maximal inhibitory concentration: 13800 nM
Estimate against measurement, compound 4: 4.6-fold (0.66 log units) below, within the range that was stated.
By their numbers in this assay, from the lowest: compound 1; then compound 2; then compound 4; then compound 3.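

In this assay, the substituent on the amide-type nitrogen turns out to be a sensitive place on the shared core: oxetan-3-yl in place of 1-(tert-butoxycarbonyl)pyrrolidin-3-yl gives a 35-fold higher number from compound 1 to compound 4 (1.54 log units; beyond the scatter). Among these compounds, this is the first step that isolates one change, so the number of compound 1 can now be tied in large part to this substituent, which goes from 12 heavy atoms to 4. Nothing measured here accounts for the size of the step.

Ring size, heavy-atom count and the presence of the tert-butoxycarbonyl group all change together in this single step, so which of them matters stays open. A free pyrrolidin-3-yl amine on the same nitrogen would separate the tert-butoxycarbonyl group from the five-membered ring.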